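A few compounds are considered here, and "the series" means these few. Any claim that something is new, unique, unknown or untested is made for them only; others in the source may bear on it.

Compound 2, `CCOC(=O)CCn1nc(-c2ccccc2)ccc1=O`, and compound 1, `CC/N=C(\S)CCn1nc(-c2ccccc2)ccc1=O`, share one core and differ only in the group carried on the chain attached to the aromatic nitrogen. Going by the values given here, in a functional assay on the whole organism (stomach) for inhibition, with Rattus norvegicus as the target, at a dose of 100 mg/kg by the intraduodenal route (a higher number here means more inhibition at the dose given (going by the name of the read-out), a lower number less inhibition), compound 1 gives 50.3%, while compound 2 gives 6.3%, the lowest of the two numbers measured; the step of a number 44 percentage points lower from compound 1 to compound 2 (beyond the scatter) is the only measured step and it stands beyond the scatter.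

Compound 3, `N=C(S)Cn1nc(-c2ccccc2)ccc1=O`, has not yet been measured in this assay. The change from compound 2 to compound 3 is a group of 3 heavy atoms (1 carbon, 1 nitrogen, 1 sulfur; no ring) in place of a group of 6 heavy atoms (4 carbon, 2 oxygen; no ring), on a saturated chain carbon bound to an aromatic nitrogen. Among the compounds with values here, this change bears directly on the one measured step: it removes the group whose arrival in compound 2 went with the large fall, and it brings back a group built from carbon, nitrogen and sulfur, as in compound 1. On that ground an increase in this assay is expected for compound 3, with the step from compound 2 estimated as a number 33.7 percentage points higher from compound 2 to compound 3 (beyond the scatter). Compound 3 is therefore expected to give about 40% in this assay, within a range from 15% to 65%.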

Compound 3, a percentage reported as inhibition, in the whole organism at one dose (the size of the read-out at that dose, not a potency): 5.5%
Estimate against measurement, compound 3: 34.5 percentage points above, and the stated range ends above it.
By their numbers in this assay, from the lowest: compounds 3 and 2 (each within the scatter of the next); then compound 1.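

In this assay there is a number 0.8 percentage points lower from compound 2 to compound 3 (within the scatter), so the group of carbon, nitrogen and sulfur in compound 3 and the (ethoxycarbonyl)methyl group in compound 2 give numbers that cannot be told apart at this position. The earlier pair suggested that the kind of atoms in the group might go with the read-out, but there is also a number 44.8 percentage points lower from compound 1 to compound 3 (beyond the scatter) and this large step shows that carbon, nitrogen and sulfur alone do not bring back the inhibition seen with compound 1, whose group of 6 heavy atoms stands apart from the shorter group of compound 3. The numbers themselves come with no measurement that would explain them.

The compounds shown leave open whether the ethyl group on the nitrogen of compound 1, the longer chain to the aromatic nitrogen, or only the two together go with its higher number. They also leave open whether sulfur is needed in the group of compound 1, which an amide with oxygen in its place on the same chain would address.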